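The compounds below may be only part of what the source reports. "The series", "measured", "known", "first", "only" and "open" are said of these compounds alone.

Measured in a functional assay on HeLa cells (Homo sapiens) for cytotoxicity, read by MTT assay; a lower number here means a stronger inhibitor, a higher number a weaker inhibitor:
- compound 1 `CC(C)=CC[C@@H](OC[C@H](C)O)C1=CC(=O)c2c(O)ccc(O)c2C1=O`: 40300 nM
- compound 2 `CC[C@](C)(O)CC(=O)O[C@H](CC=C(C)C)C1=CC(=O)c2c(O)ccc(O)c2C1=O`: 30200 nM
- compound 3 `CCCCC(CC(=O)O[C@H](CC=C(C)C)C1=CC(=O)c2c(O)ccc(O)c2C1=O)OC(C)=O`: 73500 nM

The value of compound 3 lies within the usual scatter of the value of compound 1, but it stands clear of the value of compound 2. Compound 4 `CC(C)=CC[C@@H](OC(=O)CC(C)(O)C(C)C)C1=CC(=O)c2c(O)ccc(O)c2C1=O` has not yet been measured. It carries 1-hydroxy-1,2-dimethylpropyl in place of 1-acetoxypentyl on a saturated chain carbon bound to a carbonyl carbon.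

The most relevant evidence is a 2.4-fold higher number from compound 2 to compound 3 (0.39 log units; beyond the scatter). That modest step put the same 1-acetoxypentyl in place of 1-hydroxy-1-methylpropyl, a group whose name is close to that of the group now entering. The other measured change, a 1.3-fold lower number from compound 1 to compound 2 (0.13 log units; within the scatter), stayed within the scatter and bears on this change only loosely. Compound 4 should therefore largely undo the modest step, and a similar move to a lower number is expected in this assay, estimated as a 2.1-fold lower number from compound 3 to compound 4 (0.32 log units; beyond the scatter). Compound 4 is expected at about 35000 nM, with an estimated range of 18000 nM to 65000 nM.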

Compound 4, half-maximal inhibitory concentration: 27700 nM
Beside the measured number, compound 4's estimate is 1.3-fold (0.10 log units) above it; measured number inside the range.
By their numbers in this assay, from the lowest: compounds 4, 2, 1 and 3 (each within the scatter of the next, the first and the last beyond it).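

In this assay, placing 1-hydroxy-1,2-dimethylpropyl where 1-acetoxypentyl stood, on a saturated chain carbon bound to a carbonyl carbon, gives a clear change (a 2.7-fold lower number from compound 3 to compound 4 (0.42 log units; beyond the scatter)), so a second hydroxy-bearing group also lands away from compound 3. The two hydroxy-bearing groups cannot be told apart at this place (a 1.1-fold lower number from compound 2 to compound 4 (0.04 log units; within the scatter)), and the (2-hydroxy-2,3-dimethylbutyl)carbonyl group of compound 4 cannot be told apart from the 2-hydroxypropyl group of compound 1 (a 1.5-fold lower number from compound 1 to compound 4 (0.16 log units; within the scatter)). No measurement shown here explains these differences.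

On these data alone, whether the change follows the acetoxy group or the longer chain stays open, since 1-acetoxypentyl carries both. Also open, as far as these compounds go, is what a plain pentyl chain or an amine would do at this place.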